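The compounds below may be only part of what the source reports. "The series", "measured", "known", "first", "only" and "open" are said of these compounds alone.

Measured compounds in a toxicity assay on PC-12 cells (Rattus norvegicus) for cytotoxicity, read by MTT assay; a lower number here means a stronger inhibitor, a higher number a weaker inhibitor:
Compound 1 `Cc1ccc(-n2nc(-c3ccc(C(F)(F)F)cc3O)nc2-c2ccccc2O)cc1` gives 113000 nM.
Compound 2 `CCc1ccc(-n2nc(-c3ccc(C(F)(F)F)cc3O)nc2-c2ccccc2O)cc1` gives 147000 nM.
Compound 3 `Oc1cc(C(F)(F)F)ccc1-c1nc(-c2ccccc2O)n(-c2ccc(Br)cc2)n1` gives 66800 nM.

Compound 2 gives the highest of the three numbers. Its nearest neighbour is compound 1, with a 1.3-fold higher number from compound 1 to compound 2 (0.11 log units; within the scatter) lying within the scatter; its furthest is compound 3, with a 2.2-fold lower number from compound 2 to compound 3 (0.34 log units; beyond the scatter) a modest step beyond it. Compound 4 `Cc1ccc(-n2nc(-c3ccc(C(F)(F)F)cc3O)nc2-c2ccccc2O)c(C)c1` is the next compound in this assay, and it differs from compound 2 by 2,4-dimethylphenyl in place of 4-ethylphenyl on an aromatic nitrogen. For the measured compounds named here, none of the measured steps rearranges the same atoms within this ring; the only steps touching this position either lie within the scatter or are modest. The step from compound 2 to compound 4 is therefore expected to be a 1.2-fold lower number from compound 2 to compound 4 (0.09 log units; within the scatter), within the scatter. Compound 4 is estimated at 120000 nM, within 60000 nM to 250000 nM.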

Compound 4, half-maximal inhibitory concentration: 231000 nM
The estimate for compound 4 lay 1.9-fold (0.28 log units) below the measured number; the range from low to high includes it.
By their numbers in this assay, from the lowest: compounds 3, 1, 2 and 4 (each within the scatter of the next, the first and the last beyond it).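

In this assay, rearranging the same atoms from 4-ethylphenyl to 2,4-dimethylphenyl on the aromatic nitrogen gives a 1.6-fold higher number from compound 2 to compound 4 (0.20 log units; within the scatter), whereas adding one methyl on an aromatic carbon gives a 2.0-fold higher number from compound 1 to compound 4 (0.31 log units; beyond the scatter), a modest step. Exchanging 4-bromophenyl for 2,4-dimethylphenyl gives a 3.5-fold higher number from compound 3 to compound 4 (0.54 log units; beyond the scatter), also modest and the largest step at this position among these compounds. No available evidence bears on these steps. As far as these compounds go, whether an amine, a carboxylic acid or a longer chain on this phenyl ring would shift the number remains open.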